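Adding a Methoxy Group to a Cinnamamide Core

A few compounds are considered here, and "the series" means these few. Any claim that something is new, unique, unknown or untested is made for them only; others in the source may bear on it.

Compound 1 `COc1cc(CNC(=O)/C=C/c2cccc(OCc3nc(C)c(C)nc3C)c2)ccc1OCc1nc(C)c(C)nc1C` and compound 2 `COc1cc(CNC(=O)/C=C/c2ccc(OC)c(OCc3nc(C)c(C)nc3C)c2)ccc1OCc1nc(C)c(C)nc1C` share one core and differ in a single spot: methoxy in place of hydrogen on an aromatic carbon. In a functional assay on SH-SY5Y cells (Homo sapiens) for cytotoxicity, read by MTT assay, with stated times of 24 h and 4 h (a higher number here means that more compound is needed for the effect, a lower number that less compound is needed), compound 1 gives 8700 nM, and compound 2 gives 11600 nM. That single addition produced a 1.3-fold higher number from compound 1 to compound 2 (0.12 log units; within the scatter), so the two numbers cannot be told apart with confidence.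

Compound 3 `COc1cc(/C=C/C(=O)NCc2ccc(O)c(OC)c2)cc(OC)c1` is built on a different core; the difference between the two cores is not broken down here. In this assay compound 3 gives 4860 nM, the lowest of the three measured numbers, though only the gap to compound 2 lies beyond the usual scatter.

Compound 4 `COc1cc(CNC(=O)/C=C/c2cc(OC)c(OC)c(OC)c2)ccc1O` has not yet been measured. It differs from compound 3 in one place: methoxy in place of hydrogen on an aromatic carbon. Within the data shown here, this is the same kind of change as the one that separates compound 1 from compound 2, but the surroundings are not identical. In compound 2 the new methoxy is ortho to a (3,5,6-trimethylpyrazin-2-yl)methoxy group, whereas in compound 4 it is ortho to two methoxy groups; in both it is para to a large group.

Because a 1.3-fold higher number from compound 1 to compound 2 (0.12 log units; within the scatter) stayed within the scatter, the step is expected to be a 1.2-fold higher number from compound 3 to compound 4 (0.09 log units; within the scatter). Compound 4 is therefore estimated at 6000 nM, most likely falling between 2500 nM and 15000 nM.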

Compound 4, half-maximal effective concentration: 5910 nM
Beside the measured number, compound 4's estimate is 1.0-fold (0.01 log units) above it, within the range that was stated.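

In this assay, putting methoxy in place of hydrogen on an aromatic carbon gives a 1.2-fold higher number from compound 3 to compound 4 (0.08 log units; within the scatter), and set beside the earlier step on the other core, the two agree: the same change on two cores in this assay, a 1.3-fold higher number (0.12 log units; within the scatter) from compound 1 to compound 2 and a 1.2-fold higher number (0.08 log units; within the scatter) from compound 3 to compound 4, 1.1-fold (0.04 log units) apart, within the scatter of two such steps. On these two cores, then, the change behaves alike, with the number staying inside the usual scatter each time, so the small step seen on one core was a fair guide to the step on the other. This does not show that methoxy is without any effect throughout the series, since two pairs are a small sample, each step is too small to be told from repeat measurements, and neither says why the number stays put or what would happen on a third core or at a different aromatic carbon.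

Only the exchange of hydrogen for methoxy is shown here, so it stays open whether a different group on the same aromatic carbon, such as an amine, a carboxylic acid or a longer chain like butoxy, would move the number beyond the scatter. From the compounds shown here alone, it also stays open whether the agreement between the two cores would hold for such groups.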